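This account rests on a few compounds, and the source may have more. Where it says the series, first, only, none or still open, it means among the compounds named here.

Of the compounds shown here, three have been measured in an assay on CHO cells for binding affinity to Substance-P receptor (Homo sapiens); a higher number here means a weaker inhibitor, a lower number a stronger inhibitor. Compound 1 `CN1C(=O)N(Cc2cc(C(F)(F)F)cc(C(F)(F)F)c2)C2(CCN(C(=O)c3cccc4ccccc34)CC2)C1=O` gives 457 nM in this assay, compound 2 `CN1C(=O)N(Cc2cc(C(F)(F)F)cc(C(F)(F)F)c2)C2(CCN(C(=O)c3ccccc3F)CC2)C1=O` gives 1480 nM, and compound 3 `CSc1ccc(N2C(=O)NC3(CCN(C(=O)c4cc(C(F)(F)F)cc(C(F)(F)F)c4)CC3)C2=O)cc1` gives 132 nM. Compound 3 stands lowest of the three and is therefore the strongest inhibitor among them; its gap to compound 1 and its gap to compound 2 both lie beyond the usual scatter. For the measured compounds named here, the only step between two compounds that differ in a single place runs from compound 1 to compound 2: a 3.2-fold higher number from compound 1 to compound 2 (0.51 log units; beyond the scatter). That change sits on a carbonyl carbon, not on the ring nitrogen of the five-membered ring, so it does not speak directly to the change now in question.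

Compound 4 `CCCCCCCCN1C(=O)NC2(CCN(C(=O)c3cc(C(F)(F)F)cc(C(F)(F)F)c3)CC2)C1=O` has not yet been measured. It differs from compound 3 in one place: octyl in place of 4-(methylsulfanyl)phenyl on an amide-type nitrogen in a ring. Going by the values given here, no measured pair shows what happens when an aromatic group on this ring nitrogen gives way to a plain chain, so the expectation rests on little. Compound 4 is expected to give about 400 nM in this assay, within a wide range from 100 nM to 2000 nM. That estimate means an expected step of a 3.0-fold higher number from compound 3 to compound 4 (0.48 log units; beyond the scatter), toward a weaker inhibitor, with large uncertainty.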

Compound 4, inhibition constant: 2040 nM
Estimate against measurement, compound 4: 5.1-fold (0.71 log units) below; measured number outside the range, above it.
By their numbers in this assay, from the lowest: compound 3; then compound 1; then compounds 2 and 4 (each within the scatter of the next).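

In this assay this ring nitrogen proves sensitive to what it carries: octyl in place of 4-(methylsulfanyl)phenyl gives a 15-fold higher number from compound 3 to compound 4 (1.19 log units; beyond the scatter) and moves the compound toward a weaker inhibitor. The group that leaves and the group that enters have the same count of heavy atoms, so that count alone does not set the number at this position; what differs is that the leaving group has a six-membered aromatic ring and a sulfur atom, while octyl has no ring and only carbon. No measurement at hand tells which of these differences accounts for the step.

The compounds shown leave open whether the ring itself or the methylsulfanyl group on it matters more, a question that a plain phenyl group on the same nitrogen could help to answer. They also leave open how far the number depends on chain length, and how a shorter chain such as butyl or an octyl chain ending in an amine would compare with compound 4 in this assay.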